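The source may hold more compounds than are shown below. What is called first, only, known or untested is meant among the compounds shown, and "the series" means these compounds.

Measured compounds in a functional assay on A-375 cells (Homo sapiens) for antiproliferative activity, read by MTT assay, with a stated time of 72 h; a higher number here means a weaker inhibitor, a lower number a stronger inhibitor:
compound 1 `COc1ncc(-c2ccc3c(c2)N(c2ccc(C)cc2)C(=O)CO3)cc1NS(=O)(=O)c1ccc(F)cc1`, compound 1 gives 12900 nM
compound 2 `Cc1ccc(N2C(=O)COc3ccc(-c4cnc(Cl)c(NS(=O)(=O)c5ccc(F)cc5)c4)cc32)cc1`, compound 2 gives 38900 nM
compound 3 `O=C1COc2ccc(-c3cnc4ccccc4c3)cc2N1c1ccc(Cl)cc1`, compound 3 returns only a limit of the assay, > 40000 nM

Compound 1 stands at the lowest of the two numbers in this assay; compound 2 is the nearest, with a 3.0-fold higher number from compound 1 to compound 2 (0.48 log units; beyond the scatter). Among the measured compounds shown here, compound 3 sits at the limit of > 40000 nM in this assay, at which 1 of the 3 values shown sits, and differs from compound 1 in more than one place, so it gives no single step.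

Compound 4 `COc1ncc(-c2ccc3c(c2)N(C(C)C)C(=O)CO3)cc1NS(=O)(=O)c1ccc(F)cc1` has not yet been measured in this assay. It differs from compound 1 as follows: isopropyl in place of 4-methylphenyl on an amide-type nitrogen in a ring. For the measured compounds named here, no measured step bears on this change. Going by the values given here, the only step in hand concerns the substituent on an aromatic carbon, not the amide-type nitrogen in the ring, and the remaining compound returns only a limit. The expectation therefore rests on compound 1 alone, which already gives 12900 nM, a high number in this assay.

The value for compound 4 in this assay is estimated at 25000 nM, within 8000 nM to 70000 nM. This estimate corresponds to an expected 1.9-fold higher number from compound 1 to compound 4 (0.29 log units; within the scatter), a step that may or may not pass the scatter, with a fair chance that only a limit is reported.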

Compound 4, half-maximal inhibitory concentration: 9950 nM
For compound 4 the middle estimate is 2.5-fold (0.40 log units) above the measured one; the measured number falls inside the stated range.
By their numbers in this assay, from the lowest: compounds 4 and 1 (each within the scatter of the next); then compound 2. At a limit, above all of these: compound 3.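

In this assay, isopropyl in place of 4-methylphenyl on the amide-type nitrogen in the ring gives a 1.3-fold lower number from compound 1 to compound 4 (0.11 log units; within the scatter). At this position, therefore, the six-membered aromatic ring of the 4-methylphenyl group can be given up, and the substituent cut from 7 heavy atoms to 3, without a step that passes the scatter. This is the first information on this nitrogen, since the earlier step concerned only chloro in place of methoxy on an aromatic carbon, and no measurement shown accounts for the result.

Still open, as far as these compounds go, is whether a longer chain, an amine or a carboxylic acid on this nitrogen would give a step beyond the scatter. Also open, from the compounds shown here alone, is whether isopropyl here gives the same outcome with chloro in place of methoxy.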